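From 2-methylphenyl to 4-methoxyphenyl on one shared core

A few compounds are considered here, and "the series" means these few. Any claim that something is new, unique, unknown or untested is made for them only; others in the source may bear on it.

Of the compounds shown here, three sharing one core have been measured in a functional assay on HeLa cells (Homo sapiens) for antiproliferative activity, read by sulforhodamine B assay, with a stated time of 72 h (on this read-out lower numbers stand for stronger inhibition and higher numbers for weaker inhibition), so far. Compound 2 `NC(=S)N/N=C/c1ccc2ccccc2n1` carries only hydrogen on the amide-type nitrogen and gives 960 nM as its value. Compound 1 `N#Cc1ccc(NC(=S)N/N=C/c2ccc3ccccc3n2)cc1` carries 4-cyanophenyl there and gives 20000 nM as its value. Compound 3 `Cc1ccccc1NC(=S)N/N=C/c1ccc2ccccc2n1` carries 2-methylphenyl and stands at a limit of the assay (> 100000 nM), not at a number.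

Compound 4 `COc1ccc(NC(=S)N/N=C/c2ccc3ccccc3n2)cc1` has 4-methoxyphenyl in place of 2-methylphenyl on an amide-type nitrogen. Among the compounds with values here, three measured steps bear on this change. Hydrogen in place of 4-cyanophenyl gave a 21-fold lower number from compound 1 to compound 2 (1.32 log units; beyond the scatter) in this assay and 2-methylphenyl in place of hydrogen gave an at least 100-fold higher number from compound 2 to compound 3 (2.01 log units; beyond the scatter) on the same read-out. Both phenyl compounds thus lie on the weak side of compound 2. The closest comparison is 2-methylphenyl in place of 4-cyanophenyl, which gave an at least 5.0-fold higher number from compound 1 to compound 3 (0.69 log units; beyond the scatter) on that read-out. Within the data shown here, compound 1 is the only phenyl compound with a true number, so it serves as the guide. A modest or larger move to a lower number is therefore expected from the limit of compound 3.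

The expected change is an at least 5.0-fold lower number from compound 3 to compound 4 (0.69 log units; beyond the scatter) for this replacement. Compound 4 is estimated at 20000 nM with an expected range of 4000 nM to 90000 nM in this assay once it is measured.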

Compound 4, half-maximal inhibitory concentration: 72600 nM
The estimate for compound 4 lay 3.6-fold (0.56 log units) below the measured number, within the range that was stated.
By their numbers in this assay, from the lowest: compound 2; then compound 1; then compound 4. At a limit, above all of these: compound 3.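

In this assay, 4-methoxyphenyl in place of hydrogen on the amide-type nitrogen gave a 76-fold higher number from compound 2 to compound 4 (1.88 log units; beyond the scatter), so a second phenyl compound with a true number now lies on the weak side of compound 2. Within the data shown here, the position also responds to what the phenyl ring carries: methoxy in place of cyano on an aromatic carbon gave a 3.6-fold higher number from compound 1 to compound 4 (0.56 log units; beyond the scatter), a comparison of a single ring substituent that the earlier compounds did not offer. Against compound 3, 4-methoxyphenyl in place of 2-methylphenyl gave an at least 1.3-fold lower number from compound 3 to compound 4 (0.13 log units; that floor lies within the scatter), which is only a floor set by a limit of the assay and does not separate the two groups: the limit of > 100000 nM in this assay, at which 1 of the 4 values shown sits.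

The compounds shown leave open whether any group larger than hydrogen on this nitrogen can keep the value of compound 2, for instance a methyl or a longer alkyl chain with no ring at all. They also leave open how a phenyl ring carrying an amine or a carboxylic acid would fall relative to the methoxy and cyano compounds.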